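This account rests on a few compounds, and the source may have more. Where it says the series, first, only, none or still open, it means among the compounds named here.

Measured so far, in a functional assay on HepG2 cells (Homo sapiens) for cytotoxicity, read by MTT assay, with a stated time of 48 h; on this read-out higher numbers stand for weaker inhibition and lower numbers for stronger inhibition:
Compound 1 `COc1cc(-c2nnc3n2NC(c2ccco2)C(C(=O)c2ccc(F)cc2)S3)cc(OC)c1OC` gives > 100000 nM, which is a limit of the assay and not a number.
Compound 2 `COc1cc(-c2nnc3n2NC(c2ccco2)C(C(=O)c2ccc([N+](=O)[O-])cc2)S3)cc(OC)c1OC` gives 87800 nM.

For the measured compounds named here, compound 2 therefore holds the only number in this assay; the other value shown is a limit. Going by the values given here, the single measured step, an at least 1.1-fold lower number from compound 1 to compound 2 (0.05 log units; that floor lies within the scatter), sits at the limit of > 100000 nM in this assay, at which 1 of the 2 values shown sits, and stays within the scatter. Compound 3 `COc1cccc(C(=O)C2Sc3nnc(-c4cc(OC)c(OC)c(OC)c4)n3NC2c2ccco2)c1` differs from compound 2 by 3-methoxyphenyl in place of 4-nitrophenyl on a carbonyl carbon. Among the compounds with values here, no measured step covers a methoxyphenyl in place of a nitrophenyl on the carbonyl carbon, and the only step, fluoro to nitro on the same aromatic ring, did not move the number beyond the scatter. No step beyond the scatter is therefore expected in this assay, in either direction. Compound 3 is expected at 100000 nM, between 40000 nM and 250000 nM, with a fair chance that only a limit is reported. The expected step of a 1.1-fold higher number from compound 2 to compound 3 (0.06 log units; within the scatter) lies within the scatter.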

Compound 3, half-maximal inhibitory concentration: > 100000 nM
Compound 3 was reported as a limit; the forecaster's own chance of this, stated with the estimate: 50%; the middle value sits exactly at the limit.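

In this assay, for the compounds shown here, 3-methoxyphenyl in place of 4-nitrophenyl on a carbonyl carbon gives an at least 1.1-fold higher number from compound 2 to compound 3 (0.05 log units; that floor lies within the scatter), so a change of both the substituent and its ring position yields no step that can be read as beyond the scatter. Compound 3 gives > 100000 nM, which is a limit of the assay and not a number, and the step between the two limits of compound 1 and compound 3 cannot be read. With 4-fluorophenyl, 4-nitrophenyl and 3-methoxyphenyl now shown on this carbonyl carbon, the series stays pressed against a single ceiling: the limit of > 100000 nM in this assay, at which 2 of the 3 values shown sit.

Open, as far as these compounds go, is whether an amine or a carboxylic acid on this aromatic ring, or a longer chain in its place, would give a clear step towards stronger inhibition. Equally open, from the compounds shown here alone, is whether a change elsewhere on the shared core would do so.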